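This account rests on a few compounds, and the source may have more. Where it says the series, first, only, none or still open, it means among the compounds named here.

Measured so far, in a functional assay on MCF7 cells (Homo sapiens) for antiproliferative activity, read by sulforhodamine B assay, with a stated time of 72 h; a lower number here means a stronger inhibitor, a higher number a weaker inhibitor:

Compound 1 `CC(C)C[C@H](NC(=O)CSc1cc(NS(=O)(=O)c2cccs2)c2ccccc2c1O)B(O)O` gives 9450 nM.
Compound 2 `CC(=O)Nc1ccc(S(=O)(=O)Nc2cc(SCC(=O)N[C@@H](CC(C)C)B(O)O)c(O)c3ccccc23)cc1` gives 8660 nM.
Compound 3 `CC(C)C[C@H](NC(=O)CCSc1cc(NS(=O)(=O)c2cccs2)c2ccccc2c1O)B(O)O` gives 6470 nM.

All three numbers lie close together, and none of the gaps between them is beyond the usual scatter, so no order among them can be read off. One structural change has been measured directly: from compound 1 to compound 2 the change is 4-acetamidophenyl in place of thiophen-2-yl on a sulfonyl sulfur, and the step it made was a 1.1-fold lower number from compound 1 to compound 2 (0.04 log units; within the scatter), a change too small to count.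

Compound 3 shares the boronic acid part and the sulfonamide with compound 1, but the two cores differ in a way that is not broken down here. Compound 4 `CC(=O)Nc1ccc(S(=O)(=O)Nc2cc(SCCC(=O)N[C@@H](CC(C)C)B(O)O)c(O)c3ccccc23)cc1` is compound 3 with the change (4-acetamidophenyl in place of thiophen-2-yl on a sulfonyl sulfur). The place where the change sits is described in the same words for both pairs, so this is the same change, now made on the core of compound 3.

Since the earlier step was a 1.1-fold lower number from compound 1 to compound 2 (0.04 log units; within the scatter), the expected step from compound 3 to compound 4 is similarly small, a 1.1-fold lower number from compound 3 to compound 4 (0.03 log units; within the scatter), and compound 4 is estimated to give 6000 nM in this assay, with a likely range from 3000 nM to 12000 nM.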

Compound 4, half-maximal inhibitory concentration: 6620 nM
Compound 4: middle estimate off by 1.1-fold (0.04 log units), on the low side; measured number inside the range.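

Across the two cores, 4-acetamidophenyl in place of thiophen-2-yl on a sulfonyl sulfur behaves the same way in this assay, with the new step being a 1.0-fold higher number from compound 3 to compound 4 (0.01 log units; within the scatter), and the two steps agree: the same change on two cores in this assay, a 1.1-fold lower number (0.04 log units; within the scatter) from compound 1 to compound 2 and a 1.0-fold higher number (0.01 log units; within the scatter) from compound 3 to compound 4, 1.1-fold (0.05 log units) apart, within the scatter of two such steps The other new pair differs in the group on a saturated chain carbon bound to a sulfur, and its step, a 1.3-fold lower number from compound 2 to compound 4 (0.12 log units; within the scatter), is also too small to count. So this swap left the number effectively unchanged on both cores, but two cores cannot show that it would do so on every core in the series, and two steps that are both this small say nothing about why the swap makes no visible difference.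

Going by these compounds, it remains open whether a group on the sulfonyl sulfur that carries an amine or a carboxylic acid would give a step beyond the scatter. A longer chain on the sulfur bound to the core is equally untested among these four compounds, as is any replacement of the boronic acid.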